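Pyrrolidine-triazole hydroxamates: carboxy to hydroxymethyl exchange

This account rests on a few compounds, and the source may have more. Where it says the series, first, only, none or still open, it means among the compounds named here.

Measured so far:
- compound 1 `O=C(NO)c1ccc(-c2cn([C@@H]3C[C@H](C(=O)O)N(CCCc4ccccc4)C3)nn2)cc1`, in an assay on Sf9 cells for inhibition of histone deacetylase 11 (Homo sapiens), read by fluorescence, tested at 0.5 uM (a lower number here means less inhibition, a higher number more inhibition at the concentration tested (going by the name of the read-out)), compound 1 gives < 10%, a limit of the assay and not a number.
- compound 2 `O=C(NO)c1ccc(-c2cn([C@@H]3C[C@H](C(=O)O)N(Cc4ccccc4)C3)nn2)cc1`, in this assay compound 2 gives < 10%, likewise a limit.
- compound 3 `O=C(/C=C/c1cn([C@@H]2C[C@@H](CO)N(Cc3ccccc3)C2)nn1)NO`, in this assay compound 3 gives < 10%, again a limit.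

Compound 1 therefore stands at the limit, as do the other two values shown: the limit of < 10% in this assay, at which 3 of the 3 values shown sit. For the measured compounds named here, the one step among measured compounds, a step that the two limits leave unreadable from compound 1 to compound 2, runs between two limits and its size cannot be read. Going by the values given here, compound 3 already carries a hydroxymethyl group and also sits at the limit, though it differs from compound 1 in more than one place, so no step to it is given.

The unmeasured compound 4 `O=C(NO)c1ccc(-c2cn([C@@H]3C[C@H](CO)N(CCCc4ccccc4)C3)nn2)cc1` differs from compound 1 by hydroxymethyl in place of carboxy on a saturated ring carbon; the carboxy leaves and a hydroxymethyl enters on a saturated ring carbon of the five-membered non-aromatic ring. Among the compounds with values here, no measured step bears readably on this exchange. With all three values at the limit, compound 4 is expected to remain there as well, so the step that the limit leaves unreadable from compound 1 to compound 4 is estimated to be none beyond the scatter. Compound 4 is estimated at 5%, with a range from 0% to 15% in this assay.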

Compound 4, a percentage reported as inhibition, at one concentration (the size of the read-out at that concentration, not a potency): 15%
Compound 4: middle estimate off by 10 percentage points, on the low side, within the range that was stated.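

Hydroxymethyl in place of carboxy at this saturated ring carbon, next to the ring atom that bears the 3-phenylpropyl group, gives in this assay a number at least 5 percentage points higher from compound 1 to compound 4 (that floor lies within the scatter). From the compounds shown here alone, with compound 1 held at a limit, the true size of this step stays unknown, and its floor alone does not establish a gain. Even so, compound 4 is the only compound shown to give a number rather than a limit, while the others stay at that limit: the limit of < 10% in this assay, at which 3 of the 4 values shown sit.

Going by these compounds, it remains open whether an aminomethyl group, a primary carboxamide or a methyl ester at this ring carbon would also give a number in this assay. Also open, on these data alone, is whether hydroxymethyl would lift the core of compound 2, with its different group on the ring nitrogen, off the limit.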